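The source may report more compounds than this note shows. Statements on the series, on what has been measured and on what is new or still open speak of the compounds shown alone.

Of the compounds shown here, three with a shared core have been measured in an ADME assay on the whole organism (strain FVB) for pharmacokinetics, with Mus musculus as the target, read by LC-MS, at a dose of 30 mg/kg by the oral route; a higher number here means more compound in the circulation at the dose given, a lower number less compound in the circulation. Compound 1 `NCCOc1ccc([C@H]2CC[C@]3(CC2)OOC2(O3)C3CC4CC(C3)CC2C4)cc1` gives 1370 ng.h/mL, compound 2 `c1cc([C@H]2CC[C@]3(CC2)OOC2(O3)C3CC4CC(C3)CC2C4)ccc1OCCOC1CCNCC1` gives 9180 ng.h/mL, and compound 3 `CC(C)(O)CNCCCOc1ccc([C@H]2CC[C@]3(CC2)OOC2(O3)C3CC4CC(C3)CC2C4)cc1` gives 11100 ng.h/mL. Compound 3 therefore stands level with compound 2, at a 1.2-fold higher number from compound 2 to compound 3 (0.08 log units; within the scatter), and clear of compound 1, at an 8.1-fold higher number from compound 1 to compound 3 (0.91 log units; beyond the scatter). Replacing the amino group in a different way gives a step of similar size, a 6.7-fold higher number from compound 1 to compound 2 (0.83 log units; beyond the scatter).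

Compound 4 `CC(C)(O)CN1CCC(Oc2ccc([C@H]3CC[C@]4(CC3)OOC3(O4)C4CC5CC(C4)CC3C5)cc2)CC1` differs from compound 3 as follows: 1-(2-hydroxy-2-methylpropyl)piperidin-4-yl in place of 3-((2-hydroxy-2-methylpropyl)amino)propyl on an oxygen on an aromatic ring. It keeps the 2-hydroxy-2-methylpropyl end of compound 3 and gains the piperidin-4-yl ring seen in compound 2. Going by the values given here, no measured step makes this exact change, so the forecast is loose. Since compound 2 and compound 3 sit together despite different end groups, with a 1.2-fold higher number from compound 2 to compound 3 (0.08 log units; within the scatter), no large move is expected in this assay. The estimated step is a 1.2-fold lower number from compound 3 to compound 4 (0.09 log units; within the scatter), which would be no change beyond the scatter. For compound 4 the expected value is 9000 ng.h/mL, with an estimated range of 3000 ng.h/mL to 25000 ng.h/mL.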

Compound 4, area under the concentration-time curve: 14200 ng.h/mL
For compound 4 the middle estimate is 1.6-fold (0.20 log units) below the measured one; measured number inside the range.
By their numbers in this assay, from the lowest: compound 1; then compounds 2, 3 and 4 (each within the scatter of the next).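

In this assay, a 1-(2-hydroxy-2-methylpropyl)piperidin-4-yl group can take the place of the open 3-((2-hydroxy-2-methylpropyl)amino)propyl chain on the oxygen on the aromatic ring with no change beyond the scatter, at a 1.3-fold higher number from compound 3 to compound 4 (0.11 log units; within the scatter). Compound 4 also stands level with compound 2, at a 1.5-fold higher number from compound 2 to compound 4 (0.19 log units; within the scatter), so a piperidine ring placed directly on that oxygen and one held out on a chain cannot be told apart here, while the distance to the short 2-aminoethyl chain is large, at a 10-fold higher number from compound 1 to compound 4 (1.02 log units; beyond the scatter). No measurement shown explains these numbers.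

On these data alone, how a piperidin-4-yl group without the 2-hydroxy-2-methylpropyl end would compare on that oxygen remains open. So does the effect of a morpholine ring or a carboxylic acid at the same place.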